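Bromofuranone analogue: removing the hydroxy from compound 3

The compounds below may be only part of what the source reports. "The series", "measured", "known", "first", "only" and "open" are said of these compounds alone.

Measured so far in a functional assay on A-431 cells (Homo sapiens) for cytotoxicity; a lower number here means that less compound is needed, a higher number that more compound is needed for the effect:
compound 1, `CCC[C@@H](OC(C)=O)C1=C(Br)C(=C(Br)Br)OC1=O`: "not determined" (no result reported).
compound 2, `CCCCCCC(=O)C(Br)=C(Br)Br`: > 20 ug/mL.
compound 3, `CCC[C@@H](O)C1=C(Br)C(=C(Br)Br)OC1=O`: "not determined" (no result reported).

The read-out of compound 2 is a limit of the assay, not a number: > 20 ug/mL. Compound 1 and compound 3 carry no number at all, so compound 3 stands nowhere on a scale; of the three values shown, one sits at a limit of > 20 ug/mL in this assay, at which 1 of the 3 values shown sits, and the other two are blank.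

Compound 4, `CCCCC1=C(Br)C(=C(Br)Br)OC1=O`, differs from compound 3 by hydrogen in place of hydroxy on a saturated chain carbon bound to a double-bonded ring carbon and a saturated chain carbon. Within the data shown here, no step between two measured compounds shows what such a change does here, so the numbers give neither a direction nor a size for it in this assay beyond the usual scatter. The half-maximal concentration expected for compound 4 is 15 ug/mL, within 3 ug/mL to 50 ug/mL.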

Compound 4, concentration for half-maximal effect: 10.5 ug/mL
For compound 4 the middle estimate is 1.4-fold (0.15 log units) above the measured one; the measured number falls inside the stated range.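

Compound 3 has no number in this assay to set against compound 4, so no step can be read between them. From the compounds shown here alone, what replacing 1-hydroxybutyl with butyl does to cytotoxicity in this assay stays open.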